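The source may hold more compounds than are shown below. What is called first, only, known or untested is meant among the compounds shown, and "the series" means these compounds.

Measured so far:
compound 1 `N#C[Se]c1ccc(NC(=O)OCc2ccc([N+](=O)[O-])cc2)cc1` — 68800 nM
compound 2 `N#C[Se]c1ccc(NC(=O)OCc2ccccc2)cc1` — 73700 nM
compound 3 `CCOC(=O)Nc1ccc([Se][Se]c2ccc(NC(=O)OCC)cc2)cc1` — 74300 nM

Among the measured compounds shown here, in a functional assay on CCRF-CEM cells (Homo sapiens) for cytotoxicity, read by MTT assay, with a stated time of 72 h (a lower number here means that less compound is tolerated, a higher number that more compound is tolerated), compound 2 stands second highest of the three numbers, yet all three lie within the scatter of one another, so no compound can be called more or less tolerated than another. For the measured compounds named here, the single measured step, a 1.1-fold higher number from compound 1 to compound 2 (0.03 log units; within the scatter), is itself within the scatter. Compound 4 `CC(C)COC(=O)Nc1ccc([Se]C#N)cc1` differs from compound 2 by isopropyl in place of phenyl on a saturated chain carbon bound to an oxygen next to a carbonyl group. Going by the values given here, no measured step touches this part of the molecule; the step from compound 1 to compound 2 altered a substituent on the phenyl that now leaves, and it moved the number only within the scatter. With every measured number so close together, no shift beyond the scatter is expected in this assay, namely a 1.0-fold lower number from compound 2 to compound 4 (0.01 log units; within the scatter). Compound 4 is estimated at 72000 nM, between 36000 nM and 144000 nM.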

Compound 4, concentration lethal to 50% of the cells: 68700 nM
Beside the measured number, compound 4's estimate is 1.0-fold (0.02 log units) above it, and the stated range covers the measured number.
By their numbers in this assay, from the lowest: compounds 4, 1, 2 and 3 (each within the scatter of the next).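

In this assay there is a 1.1-fold lower number from compound 2 to compound 4 (0.03 log units; within the scatter) when isopropyl takes the place of phenyl on a saturated chain carbon bound to an oxygen next to a carbonyl group. Unlike the earlier step, which altered only a substituent on the phenyl, this one removes the whole aromatic ring, and the number still stays within the scatter. Nothing available explains this result. Still open, going by these compounds, is whether an amine, a carboxylic acid or a longer chain at this place would move the number beyond the scatter.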